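Changing the amine substituent: expected cytotoxicity of compound 3

This account rests on a few compounds, and the source may have more. Where it says the series, first, only, none or still open, it means among the compounds named here.

Compound 2 `Cc1c(Cc2ccccc2)c(=O)oc2cc(OCC(O)CNCc3cccs3)ccc12` and compound 1 `Cc1c(Cc2ccccc2)c(=O)oc2cc(OCC(O)CNc3ccc(Br)cc3)ccc12` share a core and differ only in the group carried on an amine nitrogen. In an ADME assay on A549 cells (Homo sapiens) for cytotoxicity, read by CellTiter-Glo (a higher number here means that more compound is tolerated, a lower number that less compound is tolerated), compound 2 gives 87300 nM. For compound 1 the result in this assay is a limit of the assay, > 100000 nM, so no number is known for it. Among the numbers shown, compound 2 thus stands alone: its value is the only measured number, and the other result is a limit. Among the compounds with values here, the one measured step, an at least 1.1-fold lower number from compound 1 to compound 2 (0.05 log units; that floor lies within the scatter), lies within the scatter; it rests on (the limit of > 100000 nM in this assay, at which 1 of the 2 values shown sits), so its size is a floor rather than a measured change.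

Compound 3 `Cc1c(Cc2ccccc2)c(=O)oc2cc(OCC(O)CNc3nccs3)ccc12` follows as the next step: 1,3-thiazol-2-yl in place of (thiophen-2-yl)methyl on an amine nitrogen. Within the data shown here, the only step that bears on it, from compound 1 to compound 2, also swapped the group on that amine nitrogen and left the number within the scatter. The step of a 1.1-fold higher number from compound 2 to compound 3 (0.04 log units; within the scatter) is therefore expected to stay within the scatter. In this assay compound 3 is expected to give 95000 nM, with a range from 45000 nM to 200000 nM.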

Compound 3, half-maximal cytotoxic concentration: 93000 nM
Beside the measured number, compound 3's estimate is 1.0-fold (0.01 log units) above it; the measured number falls inside the stated range.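

Within the data shown here, for the first time, a step on this amine nitrogen joins two measured numbers in this assay, and it reads a 1.1-fold higher number from compound 2 to compound 3 (0.03 log units; within the scatter). Swapping (thiophen-2-yl)methyl for 1,3-thiazol-2-yl, which has one heavy atom fewer and a second hetero atom in its five-membered aromatic ring, therefore leaves the number within the scatter, so these differences in the group do not show up as a measurable change here. The other new step, an at least 1.0-fold lower number from compound 1 to compound 3 (0.03 log units; that floor lies within the scatter), gives only a floor, not a measured size, and it too stays within the scatter, with its size resting on a limit of the assay: the limit of > 100000 nM in this assay, at which 1 of the 3 values shown sits.

The compounds shown leave open whether a different kind of group on this amine nitrogen, such as a carboxylic acid, a morpholine or a longer alkyl chain, would move the number beyond the scatter. As far as these compounds go, compound 1 carries a limit and not a number, so how far its 4-bromophenyl group really stands from the two sulfur-containing groups also remains unknown.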